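The compounds below may be only part of what the source reports. "The series", "measured", "known", "first", "only" and "open" are said of these compounds alone.

Working notes on the series.

The shared core is carried by compound 1 `C=CC(=O)Nc1cccc(NC(=O)CSc2nc(Nc3ccccc3)c3ccccc3n2)c1`, which in a functional assay on NCI-H1975 cells (Homo sapiens) for inhibition, read by MTT assay, with a stated time of 72 h (on this read-out lower numbers stand for stronger inhibition and higher numbers for weaker inhibition), gives 8120 nM. Compound 2 `C=CC(=O)Nc1cccc(NC(=O)CSc2nc(Nc3ccccc3C)c3ccccc3n2)c1` gives 9920 nM in this assay, and compound 3 `C=CC(=O)Nc1cccc(NC(=O)CSc2nc(Nc3cccc(C)c3)c3ccccc3n2)c1` gives 12100 nM. The number for compound 3 sits at the upper end of the three, but a 1.5-fold higher number from compound 1 to compound 3 (0.17 log units; within the scatter) and a 1.2-fold higher number from compound 2 to compound 3 (0.09 log units; within the scatter), so the three compounds are not separated by this assay. Likewise a 1.2-fold higher number from compound 1 to compound 2 (0.09 log units; within the scatter).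

The next compound is compound 4 `C=CC(=O)Nc1cccc(NC(=O)CSc2nc(Nc3ccc(Br)cc3)c3ccccc3n2)c1`, not yet measured. Relative to compound 3 the change is 4-bromophenyl in place of 3-methylphenyl on a nitrogen on an aromatic ring. The step that bears most directly on it is the exchange of one substituted phenyl on that same nitrogen for another, a 1.2-fold higher number from compound 2 to compound 3 (0.09 log units; within the scatter), which was within the scatter. The addition of methyl to the phenyl, a 1.5-fold higher number from compound 1 to compound 3 (0.17 log units; within the scatter), was also within the scatter. Every substituent change on this phenyl so far has left this assay unmoved, so for compound 4 no step beyond the scatter is expected in either direction. The estimate for compound 4 is therefore 11000 nM, with a range from 5000 nM to 24000 nM, which corresponds to an expected step of a 1.1-fold lower number from compound 3 to compound 4 (0.04 log units; within the scatter).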

Compound 4, half-maximal inhibitory concentration: 6280 nM
The estimate for compound 4 lay 1.8-fold (0.24 log units) above the measured number, and the stated range covers the measured number.
By their numbers in this assay, from the lowest: compounds 4, 1, 2 and 3 (each within the scatter of the next).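

The earlier compounds shown here carried only methyl on this phenyl, and compound 4 widens the set to bromo: in this assay bromo in place of hydrogen gives a 1.3-fold lower number from compound 1 to compound 4 (0.11 log units; within the scatter) and so leaves the number within the scatter of the unsubstituted phenyl. Exchanging a methylphenyl for 4-bromophenyl gives a 1.6-fold lower number from compound 2 to compound 4 (0.20 log units; within the scatter) for the 2-methylphenyl case and a 1.9-fold lower number from compound 3 to compound 4 (0.28 log units; within the scatter) for the 3-methylphenyl case; the second is the largest step among the four compounds, yet it too lies within the scatter, so a change of substituent identity as well as of methyl placement on this phenyl leaves all four compounds unseparated in this assay and no ranking can be drawn from them. Nothing measured here offers an explanation for these numbers.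

Going by these compounds, whether a group of a different kind on this phenyl, such as an amine or a carboxylic acid, would produce a step beyond the scatter remains open. Also open, on these data alone, is whether a change away from this phenyl, such as a longer chain on the shared core, would separate compounds in this assay where these substituents do not.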